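Chloro to fluoro on the core of compound 2

A few compounds are considered here, and "the series" means these few. Any claim that something is new, unique, unknown or untested is made for them only; others in the source may bear on it.

Three compounds share the hydroxythiosemicarbazone framework. Compound 3 `COc1ccc(N2CCN(CN3C(=O)/C(=N\NC(=S)NO)c4cc(Cl)ccc43)CC2)cc1` and compound 2 `CCN(CC)CN1C(=O)/C(=N\NC(=S)NO)c2cc(Cl)ccc21` carry different substituents on the ring nitrogen; the difference between the two cores is not broken down here. In an ADME assay on MT4 cells (Homo sapiens) for cytotoxicity, read by spectrophotometry, with a stated time of 5 days (a higher number here means that more compound is tolerated, a lower number that less compound is tolerated), compound 3 gives 279000 nM and compound 2 gives 562000 nM. Compound 1 `COc1ccc(N2CCN(CN3C(=O)/C(=N\NC(=S)NO)c4cc(F)ccc43)CC2)cc1` differs from compound 3 by fluoro in place of chloro on an aromatic carbon, and in this assay compound 1 gives 260000 nM, a step of a 1.1-fold lower number from compound 3 to compound 1 (0.03 log units; within the scatter). Compound 4 `CCN(CC)CN1C(=O)/C(=N\NC(=S)NO)c2cc(F)ccc21` differs from compound 2 by the same change, (fluoro in place of chloro on an aromatic carbon). Because a 1.1-fold lower number from compound 3 to compound 1 (0.03 log units; within the scatter) was within the scatter, the step from compound 2 to compound 4 is expected to be a 1.1-fold lower number from compound 2 to compound 4 (0.03 log units; within the scatter), also within the scatter. Compound 4 is therefore estimated at 520000 nM in this assay, with a likely range from 300000 nM to 900000 nM.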

Compound 4, half-maximal cytotoxic concentration: 521000 nM
Compound 4: middle estimate off by 1.0-fold (0.00 log units), on the low side, and the stated range covers the measured number.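

In this assay the new step is a 1.1-fold lower number from compound 2 to compound 4 (0.03 log units; within the scatter), and it matches the earlier one on the other core: the same change on two cores in this assay, a 1.1-fold lower number (0.03 log units; within the scatter) from compound 3 to compound 1 and a 1.1-fold lower number (0.03 log units; within the scatter) from compound 2 to compound 4, 1.0-fold (0.00 log units) apart, within the scatter of two such steps. On these two cores, then, fluoro in place of chloro on the aromatic carbon leaves the half-maximal cytotoxic concentration within the scatter, and the result carries from one core to the other. This does not show that the same would hold on a core with a different substituent on the ring nitrogen, or in any other kind of measurement.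

The compounds shown leave open how a hydrogen, a methyl or a trifluoromethyl at that aromatic carbon would compare with chloro and fluoro. They also leave open how this change would behave with a morpholine or a longer chain on the ring nitrogen.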